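A few compounds are considered here, and "the series" means these few. Any claim that something is new, unique, unknown or untested is made for them only; others in the source may bear on it.

Compound 3 `CCCSc1nc(Cl)c2c(n1)N(Cc1ccccc1)C(C(=O)NCCC1=CCc3ccccc31)N2` is one of three compounds read in a functional assay on PC-3 cells (Homo sapiens) for antiproliferative activity, read by MTT assay, with a stated time of 72 h; on this read-out higher numbers stand for weaker inhibition and lower numbers for stronger inhibition. For compound 3 that assay returned only a limit, > 64000 nM, so that compound 3 stands at the limit of > 64000 nM in this assay, at which 1 of the 3 values shown sits, rather than at a number. Compound 1 `CCCSc1nc(Cl)c2c(n1)N(Cc1ccccc1)C(C(=O)N1CCN(Cc3ccccc3)CC1)N2` gives 57300 nM in this assay, and compound 2 `CCCSc1nc(Cl)c2c(n1)N(CC1CCCCC1)C(C(=O)N1CCN(C)CC1)N2` gives 12800 nM. Compound 4 `CCCSc1nc(Cl)c2c(n1)N(Cc1ccccc1)C(C(=O)NCCCc1ccccc1)N2` has not yet been measured; it differs from compound 3 by a group of 7 heavy atoms (7 carbon; one six-membered aromatic ring of carbon only) in place of a group of 9 heavy atoms (9 carbon; one five-membered non-aromatic ring of carbon only, one six-membered aromatic ring of carbon only), on a saturated chain carbon, two bonds along the chain from an amide-type nitrogen. Since compound 3 is known only as a limit, the size of the step cannot be read from the numbers shown, and no step in this assay is expected beyond the usual scatter. Compound 4 is therefore expected to give about 60000 nM, between 25000 nM and 150000 nM. The expected step is an at least 1.0-fold lower number from compound 3 to compound 4 (0.02 log units; that floor lies within the scatter), an estimate only.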

Compound 4, half-maximal inhibitory concentration: 12700 nM
Beside the measured number, compound 4's estimate is 4.7-fold (0.67 log units) above it, and the stated range ends above it.
By their numbers in this assay, from the lowest: compounds 4 and 2 (each within the scatter of the next); then compound 1. At a limit, above all of these: compound 3.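

For the compounds shown here, at this place, on a saturated chain carbon, two bonds along the chain from an amide-type nitrogen, the earlier compounds offered no step; replacing the group with a five-membered non-aromatic ring by benzyl gives, in this assay, an at least 5.0-fold lower number from compound 3 to compound 4 (0.70 log units; beyond the scatter). That step is only a floor, because compound 3 is known as a limit and not as a number: the limit of > 64000 nM in this assay, at which 1 of the 4 values shown sits.

The compounds shown do not separate the five-membered ring from the double bond outside aromatic rings as the part that matters. From the compounds shown here alone, how a longer chain, an amine or a pyridine ring would read at this place stays open.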